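Methyl on the Pyrazole Nitrogen: A Large Drop Expected

The compounds below may be only part of what the source reports. "The series", "measured", "known", "first", "only" and "open" are said of these compounds alone.

Compound 1 `c1ccc(-c2nc[nH]n2)c(NCC2=NCCN2)c1` gives 100% in a functional assay with Alpha-1B adrenergic receptor (Homo sapiens) as the target, read by calcium flux; on this read-out higher numbers stand for larger maximal responses and lower numbers for smaller maximal responses.
Compound 2 `CCn1cc(-c2ccccc2NCC2=NCCN2)cn1` gives 0% in this assay.
Compound 3 `c1ccc(-c2cn[nH]c2)c(NCC2=NCCN2)c1` gives 72% in this assay.

Among the three measured compounds, compound 3 stands second highest. The step of a number 28 percentage points lower from compound 1 to compound 3 (beyond the scatter) separates it from compound 1, and the step of a number 72 percentage points higher from compound 2 to compound 3 (beyond the scatter) separates it from compound 2.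

Compound 4 `Cn1ccc(-c2ccccc2NCC2=NCCN2)n1` differs from compound 3 in one place: 1-methyl-1H-pyrazol-3-yl in place of 1H-pyrazol-4-yl on an aromatic carbon. The group that leaves carries one hydrogen-bond donor; the group that enters carries none and bears a methyl on an aromatic nitrogen.

Among the measured compounds shown here, two measured steps bear on this change. The step of a number 72 percentage points higher from compound 2 to compound 3 (beyond the scatter) shows that removing an ethyl from an aromatic nitrogen raised the response by a large amount; the present change adds a methyl to an aromatic nitrogen, the same kind of change in reverse. The step of a number 28 percentage points lower from compound 1 to compound 3 (beyond the scatter) shows that exchanging the five-membered ring itself shifted the response only modestly. A large fall is therefore expected, a number 57 percentage points lower from compound 3 to compound 4 (beyond the scatter). Compound 4 is estimated at 15%, within the range 0% to 45%.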

Compound 4, largest response reached (reported as maximal response), in percent of the reference or control that the assay uses: 33%
For compound 4 the middle estimate is 18 percentage points below the measured one; measured number inside the range.
By their numbers in this assay, from the lowest: compound 2; then compound 4; then compound 3; then compound 1.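

A 1-methyl-1H-pyrazol-3-yl group, with a methyl on a ring nitrogen and no hydrogen-bond donor, does not abolish the response in this assay: compound 4 still gives 33% (compound 2, with an ethyl on a ring nitrogen, gives 0%). The cost of this group is still large against both rings that carry a hydrogen-bond donor (a number 39 percentage points lower from compound 3 to compound 4 (beyond the scatter)) (a number 67 percentage points lower from compound 1 to compound 4 (beyond the scatter)). No independent measurement is available to explain these falls.

From the compounds shown here alone, the step from compound 3 to compound 4 changes both the methyl and the point at which the ring is attached, so the share of each remains open. Going by these compounds, it is also open how a longer chain such as propyl, or an amine, on the pyrazole ring would alter the response.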